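The source may hold more compounds than are shown below. What is called first, only, known or untested is meant among the compounds shown, and "the series" means these compounds.

Three basic amines on the chain of the shared core have been run through a functional assay on MCF7 cells (Homo sapiens) for antiproliferative activity, read by MTT assay, with a stated time of 72 h; a higher number here means a weaker inhibitor, a lower number a stronger inhibitor. Compound 1 `COc1cc2c(Nc3ccc(C#N)cc3)ncnc2cc1OCCCN(C)C` gives 45000 nM, and compound 2 `COc1cc2c(Nc3ccc(C#N)cc3)ncnc2cc1OCCCN1CCCC1` gives 16200 nM, a gain of a 2.8-fold lower number from compound 1 to compound 2 (0.44 log units; beyond the scatter). Compound 3 `COc1cc2c(Nc3ccc(C#N)cc3)ncnc2cc1OCCCN1CCC(O)CC1` reaches only the limit of this assay, > 100000 nM. Compound 3 therefore stands at the weak end of the numbers shown, with an at least 6.1-fold higher number from compound 2 to compound 3 (0.79 log units; beyond the scatter) and an at least 2.2-fold higher number from compound 1 to compound 3 (0.34 log units; beyond the scatter). Compound 4 `COc1cc2c(Nc3ccc(C#N)cc3)ncnc2cc1OCCCN1CCc2ccccc2C1` differs from compound 3 by 1,2,3,4-tetrahydroisoquinolin-2-yl in place of 4-hydroxypiperidin-1-yl on a saturated chain carbon, three bonds along the chain from an oxygen on an aromatic ring. Both steps into compound 3 raised the number, so a move away from the hydroxypiperidine is expected to lower it, roughly an at least 3.3-fold lower number from compound 3 to compound 4 (0.52 log units; beyond the scatter), though the limit on compound 3 leaves the size uncertain. For compound 4 the estimate in this assay is 30000 nM, within 8000 nM to 150000 nM.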

Compound 4, half-maximal inhibitory concentration: > 100000 nM
Compound 4: a limit, no number; the forecaster's own chance of this, stated with the estimate: 25%; at least 3.3-fold (0.52 log units) between middle value and limit.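

In this assay, 1,2,3,4-tetrahydroisoquinolin-2-yl on this chain carbon gives an at least 6.1-fold higher number from compound 2 to compound 4 (0.79 log units; beyond the scatter) and an at least 2.2-fold higher number from compound 1 to compound 4 (0.34 log units; beyond the scatter). Weak inhibition at this place is therefore not confined to 4-hydroxypiperidin-1-yl: compound 4, with 0 hydrogen-bond donors in the entering group and an added aromatic ring, also stands at a limit. The step from compound 3 to compound 4 cannot be read because both compounds sit at the same limit: the limit of > 100000 nM in this assay, at which 2 of the 4 values shown sit.

From the compounds shown here alone, how an unsubstituted piperidine or a morpholine would read on this chain remains open. Also open, going by these compounds, is whether a shorter chain would keep the order of compound 1 and compound 2.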